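This account rests on a few compounds, and the source may have more. Where it says the series, first, only, none or still open, it means among the compounds named here.

The shared core is carried by compound 1, `Nc1nn(C(=O)Nc2ccc(Cc3ccccc3)cc2)c2ccccc12`, and by compound 2, `Nc1nn(C(=O)Nc2ccc(Cc3ccccc3)cc2)c2ccc(Cl)cc12`, which adds a chloro group to that core. In a functional assay on CAKI-1 cells (Homo sapiens) for antiproliferative activity, read by sulforhodamine B assay, with a stated time of 48 h (a higher number here means a weaker inhibitor of growth, a lower number a stronger inhibitor of growth), compound 1 gives 58000 nM. For compound 2 this assay reports only a limit, > 100000 nM. The step of an at least 1.7-fold higher number from compound 1 to compound 2 (0.23 log units; that floor lies within the scatter) is thus known only by its floor, and the limit of > 100000 nM in this assay, at which 1 of the 2 values shown sits, marks where that limit sits. Compound 3, `Nc1ccc2c(c1)c(N)nn2C(=O)Nc1ccc(Cc2ccccc2)cc1`, arises from compound 2 by a single change: amino in place of chloro on an aromatic carbon. Among the measured compounds shown here, the one measured step at this place is the chloro entering for hydrogen on the way from compound 1 to compound 2, and its size is only a floor lying within the scatter. For the measured compounds named here, no measured step shows an amino group here, so the change in this assay is expected to be small, in either direction, an at least 1.2-fold lower number from compound 2 to compound 3 (0.09 log units; that floor lies within the scatter). Compound 3 is therefore expected to give 80000 nM, within a range from 30000 nM to 200000 nM.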

Compound 3, concentration for total growth inhibition: 26800 nM
The estimate for compound 3 lay 3.0-fold (0.47 log units) above the measured number, outside the stated range (below it).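

In this assay, this position now shows a change beyond the scatter: amino in place of chloro gives an at least 3.7-fold lower number from compound 2 to compound 3 (0.57 log units; beyond the scatter), and amino in place of hydrogen gives a 2.2-fold lower number from compound 1 to compound 3 (0.34 log units; beyond the scatter). The second step has a measured number at both ends, and it shows that an amino group here goes with stronger growth inhibition than hydrogen, which the chloro step, a floor within the scatter, could not show. The first step is known only by its floor, since compound 2 carries a limit and not a number: the limit of > 100000 nM in this assay, at which 1 of the 3 values shown sits.

The compounds shown hold only hydrogen, chloro and amino at this place, so it stays open whether a hydroxyl, a methylamino or an acetamido group would go the same way. They also leave open whether an amino group would give a similar step at another place on the shared core.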